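Trifluoromethyl for Fluoro on Two Related Cores

The source may hold more compounds than are shown below. What is called first, only, known or untested is meant among the compounds shown, and "the series" means these compounds.

Compound 1 `Cc1c(O)ccc2c1[C@H](Cn1cc(-c3ccc(F)cc3)nn1)[C@@]13CC(=O)[C@@](C)(CC[C@@H]21)C3` and compound 2 `Cc1c(O)ccc2c1[C@H](Cn1cc(-c3ccc(C(F)(F)F)cc3)nn1)[C@@]13CC(=O)[C@@](C)(CC[C@@H]21)C3` share one core; compound 3 `C=C1C[C@]23C[C@@]1(O)CC[C@@H]2c1cccc(C)c1[C@@H]3Cn1cc(-c2ccc(F)cc2)nn1` and compound 4 `C=C1C[C@]23C[C@@]1(O)CC[C@@H]2c1cccc(C)c1[C@@H]3Cn1cc(-c2ccc(C(F)(F)F)cc2)nn1` share another, and the difference between the two cores is not broken down here. In a functional assay on SMMC-7721 cells (Homo sapiens) for cytotoxicity, read by MTT assay, with a stated time of 4 days (on this read-out lower numbers stand for stronger inhibition and higher numbers for weaker inhibition), compound 1 gives only a limit of the assay, > 20000 nM. In this assay compound 2 likewise gives only a limit, > 20000 nM. The change between them, (trifluoromethyl in place of fluoro on an aromatic carbon), therefore yields a step that the two limits leave unreadable from compound 1 to compound 2, because both values sit at the limit of > 20000 nM in this assay, at which 3 of the 3 values shown sit. In this assay compound 3 also gives only a limit, > 20000 nM. The same change, (trifluoromethyl in place of fluoro on an aromatic carbon), separates compound 3 from compound 4. With compound 1 and compound 2 showing a step that the two limits leave unreadable from compound 1 to compound 2, compound 4 is expected to stay at the limit, an expected step that the limit leaves unreadable from compound 3 to compound 4. The estimate for compound 4 is 30000 nM.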

Compound 4, half-maximal inhibitory concentration: > 20000 nM
Compound 4 ended at the assay's limit (the forecaster's own chance of this, stated with the estimate: 85%); the middle value is on the limit's open side.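

Compound 3 and compound 4 both give only a limit in this assay, so no step can be read between them: the limit of > 20000 nM in this assay, at which 4 of the 4 values shown sit. The compounds shown leave open whether trifluoromethyl in place of fluoro changes cytotoxicity at all on either core.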